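This account rests on a few compounds, and the source may have more. Where it says the series, first, only, none or still open, it means among the compounds named here.

Measured set:
- compound 1 `Nc1nc(-c2cc(N3C[C@H](O)[C@@H](O)C3)ccc2O)cc(C2CCCCCC2)n1`: 600 nM in a functional assay on A549 cells (Homo sapiens) for cytotoxicity, with a stated time of 48 h; on this read-out lower numbers stand for stronger inhibition of growth and higher numbers for weaker inhibition of growth
- compound 2 `Nc1nc(NC2CCCCC2)cc(-c2cc(N3C[C@H](O)[C@@H](O)C3)ccc2O)n1`: 1500 nM
- compound 3 `Nc1nc(-c2cc(N3C[C@H](O)[C@@H](O)C3)ccc2O)cc(C2CCNCC2)n1`: "not determined" (no result reported) in this assay

Compound 3 thus has no number to stand on; its place in the series is open. Compound 4 `Nc1nc(-c2cc(N3C[C@H](O)[C@@H](O)C3)ccc2O)cc(C2CCCC2)n1` differs from it by cyclopentyl in place of piperidin-4-yl on an aromatic carbon. Within the data shown here, the only measured step that bears on the carbocycle at this position is a 2.5-fold higher number from compound 1 to compound 2 (0.40 log units; beyond the scatter), where cycloheptyl gave the lower number. Cyclopentyl in compound 4 is a carbocycle like cycloheptyl in compound 1, so a number in the region of compound 1, allowing for wider uncertainty with no value for compound 3, is expected. Compound 4 is therefore estimated at 1000 nM, with a range of 300 nM to 3500 nM.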

Compound 4, concentration for 50% growth inhibition: 2000 nM
Compound 4: middle estimate off by 2.0-fold (0.30 log units), on the low side; measured number inside the range.
By their numbers in this assay, from the lowest: compound 1; then compounds 2 and 4 (each within the scatter of the next).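

Within this assay, ring size on this aromatic carbon shifts the number: cyclopentyl in place of cycloheptyl gives a 3.3-fold higher number from compound 1 to compound 4 (0.52 log units; beyond the scatter), the first comparison of two carbon-only rings here. Cyclopentyl in place of cyclohexylamino gives a 1.3-fold higher number from compound 2 to compound 4 (0.12 log units; within the scatter), so these two groups are not separated in this read-out. Nothing available explains either step.

The step from compound 3, with piperidin-4-yl, cannot be read. Open too, as far as these compounds go, is where cyclohexyl would fall between cyclopentyl and cycloheptyl, and how an open-chain alkyl group would compare.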